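Cytotoxicity of a triazole series: a further aryl change

A few compounds are considered here, and "the series" means these few. Any claim that something is new, unique, unknown or untested is made for them only; others in the source may bear on it.

Compound 3, with the structure `Cn1cc(SCc2nnc(SCc3c(F)cccc3Cl)n2-c2c(Cl)cccc2Cl)c2ccccc21`, was tested in a toxicity assay on HEK-293T cells (Homo sapiens) for cytotoxicity, read by CCK-8 assay, with a stated time of 48 h; a lower number here means that less compound is tolerated, a higher number that more compound is tolerated. In this assay compound 3 gives > 100000 nM, which is a limit of the assay and not a number. Two close relatives share its core. Compound 1 has the structure `Cn1cc(SCc2nnc(SCc3c(Cl)cccc3Cl)n2-c2c(Cl)cccc2Cl)c2ccccc21`, and in this assay compound 1 gives > 100000 nM, again a limit. Compound 2 has the structure `Cn1cc(SCc2nnc(SCc3cccc(Cl)c3F)n2-c2c(Cl)cccc2Cl)c2ccccc21`, and in this assay compound 2 gives > 100000 nM, also a limit. The steps between them, a step that the two limits leave unreadable from compound 1 to compound 2, a step that the two limits leave unreadable from compound 1 to compound 3 and a step that the two limits leave unreadable from compound 2 to compound 3, therefore cannot be sized, because every value rests on (the limit of > 100000 nM in this assay, at which 3 of the 3 values shown sit).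

Compound 4, with the structure `Cn1cc(SCc2nnc(SCc3ccc(OC(F)(F)F)c(Cl)c3)n2-c2c(Cl)cccc2Cl)c2ccccc21`, differs from compound 3 by 3-chloro-4-(trifluoromethoxy)phenyl in place of 2-chloro-6-fluorophenyl on a saturated chain carbon bound to a sulfur. The measured steps bear on this change only in that none of them revealed any tolerated concentration below the limit. For the measured compounds named here, no direction for the step is readable from them, so the expectation is that compound 4 also stays near or beyond the limit, which means an expected step that the limit leaves unreadable from compound 3 to compound 4. Compound 4 is expected to give 150000 nM, with an estimated range from 60000 nM to 300000 nM.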

Compound 4, half-maximal cytotoxic concentration: 77700 nM
Beside the measured number, compound 4's estimate is 1.9-fold (0.29 log units) above it; the measured number falls inside the stated range.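

For the compounds shown here, compound 4 is the first compound in this set whose value in this assay is a number and not a limit: compound 4 gives 77700 nM. This shows that a change on the saturated chain carbon bound to a sulfur can bring the reading inside the range of the assay, and the change to 3-chloro-4-(trifluoromethoxy)phenyl gives an at least 1.2-fold lower number from compound 3 to compound 4 (0.10 log units; that floor lies within the scatter), an at least 1.2-fold lower number from compound 2 to compound 4 (0.10 log units; that floor lies within the scatter) and an at least 1.2-fold lower number from compound 1 to compound 4 (0.10 log units; that floor lies within the scatter), so none of the three floors by itself shows a difference greater than ordinary repeat variation. The true size of these steps cannot be read, because each of them starts from a limit and gives only a floor: the limit of > 100000 nM in this assay, at which 3 of the 4 values shown sit.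

Whether the chloro group or the trifluoromethoxy group matters more for the reading in this assay remains open, as the compounds shown include no aryl group that carries only the trifluoromethoxy group. Also open, going by these compounds, is how an amine, a carboxylic acid or a longer chain in this same place would read, and whether any of them would give a number or another limit.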